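Replacing the Nitro Group: Expected Binding of Compound 4

The compounds below may be only part of what the source reports. "The series", "measured", "known", "first", "only" and "open" are said of these compounds alone.

Compound 1, `Cc1ncccc1OC[C@@H]1CCCN1C`, gives 22.9 nM in an assay on membranes from brain for displacement of a labelled ligand from Neuronal acetylcholine receptor; alpha4/beta2 (Rattus norvegicus); on this read-out higher numbers stand for weaker inhibition and lower numbers for stronger inhibition.
Compound 2, `CN1CCC[C@H]1COc1cccnc1Br`, gives 451 nM in this assay.
Compound 3, `CN1CCC[C@H]1COc1cccnc1[N+](=O)[O-]`, gives 9000 nM in this assay.

Compound 3 has the highest number of the three; its nearest neighbour is compound 2, and the step of a 20-fold higher number from compound 2 to compound 3 (1.30 log units; beyond the scatter) is large, while a 390-fold higher number from compound 1 to compound 3 (2.59 log units; beyond the scatter) is larger still. Compound 4, `CN1CCC[C@H]1COc1cccnc1I`, differs from compound 3 by iodo in place of nitro on an aromatic carbon. The step bearing on this is a 20-fold higher number from compound 2 to compound 3 (1.30 log units; beyond the scatter), which went the other way with bromo as the halogen; a change of about that size, downward, is therefore expected, and compound 4 is estimated at 500 nM (range 150 nM to 1600 nM), a step of an 18-fold lower number from compound 3 to compound 4 (1.26 log units; beyond the scatter).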

Compound 4, inhibition constant: 606 nM
Beside the measured number, compound 4's estimate is 1.2-fold (0.08 log units) below it; measured number inside the range.
By their numbers in this assay, from the lowest: compound 1; then compounds 2 and 4 (each within the scatter of the next); then compound 3.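

At the place next to the ring nitrogen, iodo undoes most of the loss seen with nitro, as a 15-fold lower number from compound 3 to compound 4 (1.17 log units; beyond the scatter) shows in this assay, and a 1.3-fold higher number from compound 2 to compound 4 (0.13 log units; within the scatter) puts the two halogens on a par. Even so, a 26-fold higher number from compound 1 to compound 4 (1.42 log units; beyond the scatter) shows that neither halogen recovers what methyl gives at this place. (No measurement bearing on the cause of these steps is available)

The compounds shown leave open whether an amine or a hydroxyl here would come closer to compound 1. On these data alone, whether a longer chain in place of methyl would hold its number also stays open.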